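Hydrogen for tert-butoxycarbonyl: compound 2 to compound 4

This account rests on a few compounds, and the source may have more. Where it says the series, first, only, none or still open, it means among the compounds named here.

In a functional assay on HeLa cells (Homo sapiens) for inhibition, with a stated time of 72 h (a lower number here means a stronger inhibitor, a higher number a weaker inhibitor), compound 1 `CCCCCCCC/C=C\CCCCCCCCOC[C@H]1NC[C@H](O)[C@@H]1O` gives 8000 nM, compound 2 `CCCCCCCC/C=C\CCCCCCCCOC[C@@H]1C[C@@H](O)CN1C(=O)OC(C)(C)C` gives 40000 nM and compound 3 `CCCCCCCC/C=C/CCCCCCCCOC[C@@H]1C[C@@H](O)CN1C(=O)OC(C)(C)C` gives 29500 nM. Compound 2 lies within the scatter of compound 3 and beyond the scatter from compound 1, on the higher side. Compound 4 `CCCCCCCC/C=C\CCCCCCCCOC[C@@H]1C[C@@H](O)CN1` comes from compound 2 by one change: hydrogen in place of tert-butoxycarbonyl on an amine nitrogen in a ring. Among the compounds with values here, the only measured step, a 1.4-fold lower number from compound 2 to compound 3 (0.13 log units; within the scatter), concerns the fact that compounds 2 and 3 differ only in the configuration as drawn and does not touch this nitrogen. Within the data shown here, the sole guide is compound 1 at 8000 nM, which also has hydrogen on an amine nitrogen in a ring, though its core differs. A step beyond the scatter is therefore expected, estimated as a 4.0-fold lower number from compound 2 to compound 4 (0.60 log units; beyond the scatter). For compound 4 the estimated value in this assay is 10000 nM, with an expected range of 3500 nM to 30000 nM.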

Compound 4, half-maximal inhibitory concentration: 3900 nM
For compound 4 the middle estimate is 2.6-fold (0.41 log units) above the measured one, within the range that was stated.
By their numbers in this assay, from the lowest: compound 4; then compound 1; then compounds 3 and 2 (each within the scatter of the next).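

Hydrogen on the amine nitrogen in a ring is far better tolerated than tert-butoxycarbonyl: a 10-fold lower number from compound 2 to compound 4 (1.01 log units; beyond the scatter) is a large step, whereas the double-bond configuration gave only a 1.4-fold lower number from compound 2 to compound 3 (0.13 log units; within the scatter). Hydrogen in place of hydroxy on a saturated ring carbon gives a smaller change, a 2.1-fold lower number from compound 1 to compound 4 (0.31 log units; beyond the scatter), so the nitrogen substituent has the larger effect of the two changes. Nothing shown explains either step.

Going by these compounds, whether a methyl or acetyl group on this nitrogen keeps the value of compound 4 remains open. So does the effect of an amine in place of the ring hydroxy.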